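Swapping the Halogens on the Hydrazide Aryl Ring

The source may report more compounds than this note shows. Statements on the series, on what has been measured and on what is new or still open speak of the compounds shown alone.

Measured so far in this assay:
compound 1 `CC(C)(C)N(NC(=O)c1ccccc1I)C(=O)c1ccccc1Cl`: 1290 nM
compound 2 `CC(C)(C)N(NC(=O)c1ccc(F)cc1)C(=O)c1ccccc1Cl`: 389 nM

In an assay on cells for agonist activity at ecdysone receptor (Bombyx mori), read by a luciferase reporter, with a stated time of 24 h (on this read-out lower numbers stand for an effect already at smaller amounts and higher numbers for an effect only at larger amounts of compound), compound 2 holds the lower of the two numbers, separated from compound 1 by a 3.3-fold lower number from compound 1 to compound 2 (0.52 log units; beyond the scatter). Compound 3 `CC(C)(C)N(NC(=O)c1cccc(Cl)c1Cl)C(=O)c1ccccc1Cl` differs from compound 2 by 2,3-dichlorophenyl in place of 4-fluorophenyl on a carbonyl carbon. Within the data shown here, only that single step bears on this change, and it came with a halogen exchange on the same ring, so the direction is uncertain. A modest rise toward the number of compound 1 is expected, giving an estimated step of a 2.1-fold higher number from compound 2 to compound 3 (0.31 log units; beyond the scatter). Compound 3 is therefore expected at 800 nM, with a range from 250 nM to 3000 nM.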

Compound 3, half-maximal effective concentration: 9.33 nM
Compound 3: middle estimate off by 86-fold (1.93 log units), on the high side, outside the stated range (below it).
By their numbers in this assay, from the lowest: compound 3; then compound 2; then compound 1.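

In this assay, the aryl group on this carbonyl carbon proves able to shift the number much further than the first pair showed: 2,3-dichlorophenyl in place of 4-fluorophenyl gives a 42-fold lower number from compound 2 to compound 3 (1.62 log units; beyond the scatter), and in place of 2-iodophenyl it gives a 140-fold lower number from compound 1 to compound 3 (2.14 log units; beyond the scatter). All three compounds carry halogen on this ring, so among them the mere presence of halogen does not settle the result; which halogens are present, how many, and where they sit differ together. Nothing measured here explains the large gain.

On these data alone, whether 2-chlorophenyl or 3-chlorophenyl alone would keep the low number remains open, as does whether a methoxy group or a nitrile could take the place of either chlorine.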